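Isopropyl for Trifluoromethyl, Tested on a Second Core

The compounds below may be only part of what the source reports. "The series", "measured", "known", "first", "only" and "open" are said of these compounds alone.

In an assay on cells for inhibition of Palmitoleoyl-protein carboxylesterase NOTUM variant C330S (Homo sapiens), read by fluorescence, with a stated time of 40 min (on this read-out higher numbers stand for weaker inhibition and lower numbers for stronger inhibition), compound 1 `Cc1cc(C(=O)O)c(C)n1-c1cccc(C(F)(F)F)c1` gives 1500 nM, while compound 2 `Cc1cc(C(=O)O)c(C)n1-c1cccc(C(C)C)c1` gives 360 nM in this assay. The change between them is isopropyl in place of trifluoromethyl on an aromatic carbon, and it made a 4.2-fold lower number from compound 1 to compound 2 (0.62 log units; beyond the scatter). Compound 3 `O=C(O)C1CCN(c2cccc(C(F)(F)F)c2)C1` gives 11000 nM in this assay, the highest of the three numbers; how its core differs from that of compound 1 is not broken down here. Compound 4 `CC(C)c1cccc(N2CCC(C(=O)O)C2)c1` has not yet been measured. It differs from compound 3 by isopropyl in place of trifluoromethyl on an aromatic carbon, the same kind of change as that from compound 1 to compound 2, though the surroundings differ: here the group is meta to a group of 8 heavy atoms, there meta to a large group. Compound 4 is therefore expected to give 3000 nM in this assay, plausibly between 1000 nM and 9000 nM. The expected step, a 3.7-fold lower number from compound 3 to compound 4 (0.56 log units; beyond the scatter), rests on the measured step of a 4.2-fold lower number from compound 1 to compound 2 (0.62 log units; beyond the scatter), taken as a guide for a change of the same kind on a different core.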

Compound 4, half-maximal inhibitory concentration: 57000 nM
Estimate against measurement, compound 4: 19-fold (1.28 log units) below; measured number outside the range, above it.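

In this assay the step on the core of compound 3 is a 5.2-fold higher number from compound 3 to compound 4 (0.71 log units; beyond the scatter) and so runs opposite to the step on the core of compound 1. Isopropyl in place of trifluoromethyl therefore did not carry from one core to the other in this series: the same change on two cores in this assay, a 4.2-fold lower number (0.62 log units; beyond the scatter) from compound 1 to compound 2 and a 5.2-fold higher number (0.71 log units; beyond the scatter) from compound 3 to compound 4, 22-fold (1.33 log units) apart, beyond the scatter of two such steps. The two pairs do not show why the direction reverses, and two cores set no rule for a third.

The compounds shown leave open how a cyclopropyl or methoxy group on the same aromatic carbon would behave on each core. They also leave open whether the two cores would still diverge with an amide in place of the carboxylic acid.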